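Piperazinyl series: from compound 3 to compound 4

The source may report more compounds than this note shows. Statements on the series, on what has been measured and on what is new or still open speak of the compounds shown alone.

Measured in a functional assay on a cell-free system (plasma, Homo sapiens) for inhibition, with Plasma (Rattus norvegicus) as the target; a higher number here means a weaker inhibitor, a lower number a stronger inhibitor:
compound 1 `O=c1cc(N2CCNCC2)c2c(OCc3ccccc3)cccc2o1`: 187000 nM
compound 2 `Cc1c(OCc2ccccc2)ccc2c(N3CCNCC3)cc(=O)oc12`: 1900 nM
compound 3 `COc1c(C)cnc(COc2ccc3c(N4CCNCC4)cc(=O)oc3c2C)c1C`: 3300 nM

Compound 3 at 3300 nM lies within the scatter of compound 2 at 1900 nM, and compound 1 at 187000 nM stands far higher than both. Compound 4 `Cc1c(OCC2CCCN(C)C2)ccc2c(N3CCNCC3)cc(=O)oc12` differs from compound 3 in one place: 1-methylpiperidin-3-yl in place of 4-methoxy-3,5-dimethylpyridin-2-yl on a saturated chain carbon bound to an oxygen on an aromatic ring. Within the data shown here, the one measured step at this place, a 1.7-fold higher number from compound 2 to compound 3 (0.24 log units; within the scatter), exchanged one aromatic group for another. Among the measured compounds shown here, no measured compound carries a non-aromatic ring there, so the evidence is thin. No step beyond the scatter is therefore expected in this assay, and the estimated step is a 1.1-fold lower number from compound 3 to compound 4 (0.04 log units; within the scatter). For compound 4 the estimated value is 3000 nM, with an expected range of 700 nM to 13000 nM.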

Compound 4, half-maximal inhibitory concentration: 4700 nM
Compound 4: the middle estimate sits 1.6-fold (0.19 log units) below what was measured; the measured number falls inside the stated range.
By their numbers in this assay, from the lowest: compounds 2, 3 and 4 (each within the scatter of the next, the first and the last beyond it); then compound 1.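

In this assay this place, a saturated chain carbon bound to an oxygen on an aromatic ring, now carries a non-aromatic ring: 1-methylpiperidin-3-yl in place of 4-methoxy-3,5-dimethylpyridin-2-yl gives a 1.4-fold higher number from compound 3 to compound 4 (0.15 log units; within the scatter) and so leaves the number within the scatter. Among these compounds, in place of phenyl, the same group gives a 2.5-fold higher number from compound 2 to compound 4 (0.39 log units; beyond the scatter) as the first modest step beyond the scatter at this place. Nothing on hand accounts for either step.

Open, on these data alone, is whether cyclohexyl, a ring without nitrogen, would behave like 1-methylpiperidin-3-yl here. As far as these compounds go, a carboxylic acid on the same chain carbon also remains untested in these compounds.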